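Swapping amino for hydrogen on compound 3

A few compounds are considered here, and "the series" means these few. Any claim that something is new, unique, unknown or untested is made for them only; others in the source may bear on it.

- compound 1 `Nc1ccc2sc(NC(=S)NC(=O)c3ccccc3)nc2c1`: 70100 nM
- compound 2 `O=C(NC(=S)Nc1nc2ccccc2s1)c1ccccc1`: 57500 nM
- compound 3 `Nc1ccc2sc(NC(=S)NC(=O)c3ccc([N+](=O)[O-])cc3)nc2c1`: 63100 nM

These numbers come from a functional assay on HeLa cells (Homo sapiens) for cytotoxicity, read by MTT assay, with a stated time of 24 h; on this read-out higher numbers stand for weaker inhibition and lower numbers for stronger inhibition. Compound 3 lies within the scatter of both other compounds, so the three cannot be ranked. Its nitro group goes with a 1.1-fold lower number from compound 1 to compound 3 (0.05 log units; within the scatter).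

Compound 4 `O=C(NC(=S)Nc1nc2ccccc2s1)c1ccc([N+](=O)[O-])cc1` differs from compound 3 by hydrogen in place of amino on an aromatic carbon. The same swap, without the nitro group, gave a 1.2-fold lower number from compound 1 to compound 2 (0.09 log units; within the scatter). Among the compounds with values here, only that one step bears on the change, so no shift beyond the scatter is expected in this assay. The expected change is a 1.2-fold lower number from compound 3 to compound 4 (0.08 log units; within the scatter). Compound 4 is estimated at 52000 nM, with an expected range of 30000 nM to 90000 nM.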

Compound 4, half-maximal inhibitory concentration: 62600 nM
Estimate against measurement, compound 4: 1.2-fold (0.08 log units) below; low and high end bracket the measured number.
By their numbers in this assay, from the lowest: compounds 2, 4, 3 and 1 (each within the scatter of the next).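

With the nitro group present, hydrogen in place of amino on the aromatic carbon gives a 1.0-fold lower number from compound 3 to compound 4 (0.00 log units; within the scatter), so on neither core does this change shift the number beyond the scatter in this assay: the same change on two cores in this assay, a 1.2-fold lower number (0.09 log units; within the scatter) from compound 1 to compound 2 and a 1.0-fold lower number (0.00 log units; within the scatter) from compound 3 to compound 4, 1.2-fold (0.08 log units) apart, within the scatter of two such steps

The nitro group can now also be read without the amino group, giving a 1.1-fold higher number from compound 2 to compound 4 (0.04 log units; within the scatter), and again there is no shift beyond the scatter: the same change on two cores in this assay, a 1.1-fold lower number (0.05 log units; within the scatter) from compound 1 to compound 3 and a 1.1-fold higher number (0.04 log units; within the scatter) from compound 2 to compound 4, 1.2-fold (0.08 log units) apart, within the scatter of two such steps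

Still open, on these data alone, is whether a carboxylic acid or an acetamide in place of the amino group, or a methoxy group or chlorine in place of the nitro group, would move the number beyond the scatter.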